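The source may hold more compounds than are shown below. What is called first, only, known or untested is meant among the compounds shown, and "the series" means these compounds.

Compound 3 `N/C(=N/NC(CC(=O)c1ccc(-n2ccnc2)cc1)c1ccc(Br)cc1)c1ccccn1` gives the highest number of the three in an ADME assay on Vero cells (Chlorocebus sabaeus) for cytotoxicity, read by MTT assay, with a stated time of 72 h (on this read-out lower numbers stand for higher toxicity in this test and higher numbers for lower toxicity in this test), at 298000 nM. Compound 2 `N/C(=N/NC(CC(=O)c1ccc(-n2ccnc2)cc1)c1ccc(Cl)cc1)c1ccccn1` gives 78800 nM in this assay, and compound 1 `N/C(=N/NC(CC(=O)c1ccc(-n2ccnc2)cc1)c1cccc(Cl)c1)c1ccccn1` gives 68600 nM. Compound 4 `N/C(=N/NC(CC(=O)c1ccc(-n2ccnc2)cc1)c1ccccc1F)c1ccccn1` is still to be measured; the change is 2-fluorophenyl in place of 4-bromophenyl on a saturated chain carbon bound to an amine nitrogen and a saturated chain carbon. Of the measured steps, a 1.1-fold higher number from compound 1 to compound 2 (0.06 log units; within the scatter) stays within the scatter, while a 4.3-fold higher number from compound 1 to compound 3 (0.64 log units; beyond the scatter) and a 3.8-fold higher number from compound 2 to compound 3 (0.58 log units; beyond the scatter) each raise the number modestly. Going by the values given here, no measured step brings in a fluorine or a 2-fluorophenyl group, so the expectation rests on the halophenyl swaps alone. The step of a 3.0-fold lower number from compound 3 to compound 4 (0.47 log units; beyond the scatter) is expected to be a modest fall, because compound 3 at 298000 nM sits apart from compound 1 and compound 2. Compound 4 is therefore estimated at 100000 nM, within 40000 nM to 280000 nM.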

Compound 4, half-maximal cytotoxic concentration: 62100 nM
Compound 4: middle estimate off by 1.6-fold (0.21 log units), on the high side; the range from low to high includes it.
By their numbers in this assay, from the lowest: compounds 4, 1 and 2 (each within the scatter of the next); then compound 3.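

In this assay the steps of a 1.3-fold lower number from compound 2 to compound 4 (0.10 log units; within the scatter) and a 1.1-fold lower number from compound 1 to compound 4 (0.04 log units; within the scatter) stay within the scatter, which places 2-fluorophenyl with both chlorophenyl groups on this saturated chain carbon. The step of a 4.8-fold lower number from compound 3 to compound 4 (0.68 log units; beyond the scatter) leaves 4-bromophenyl as the only one of the four halophenyl groups standing apart from the rest. No measured evidence accounts for this result. Still open, going by these compounds, is whether the higher number of compound 3 follows the bromine itself or its place on the ring, and how a plain phenyl or a methoxyphenyl group would read here.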